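A few compounds are considered here, and "the series" means these few. Any claim that something is new, unique, unknown or untested is made for them only; others in the source may bear on it.

Compound 3 `COC(=O)c1nc(-c2ccoc2)n(-c2ccc(F)cc2)n1` gives 11700 nM in a functional assay on NPC-TW01 cells (Homo sapiens) for inhibition, read by MTT assay, with a stated time of 72 h (on this read-out higher numbers stand for weaker inhibition of growth and lower numbers for stronger inhibition of growth), the lowest of the numbers at hand; the nearest is compound 2 `COC(=O)c1nc(C2CC2)n(-c2ccc(F)cc2)n1`, which gives 95900 nM. Compound 1 `COC(=O)c1nc(C(C)C)n(-c2ccc(F)cc2)n1` reaches only a limit of this assay, > 100000 nM. The change leading to compound 4 `COC(=O)c1nc(-c2ccsc2)n(-c2ccc(F)cc2)n1` is thiophen-3-yl in place of furan-3-yl on an aromatic carbon. The steps recorded so far each replace an alkyl group with the furan-3-yl group: an at least 8.5-fold lower number from compound 1 to compound 3 (0.93 log units; beyond the scatter) and an 8.2-fold lower number from compound 2 to compound 3 (0.91 log units; beyond the scatter). Among the compounds with values here, no recorded step exchanges one five-membered heteroaryl ring for another, so those steps bear only loosely on the present change. Compound 4 is expected to show a step of about a 1.2-fold lower number from compound 3 to compound 4 (0.07 log units; within the scatter), a move within the scatter. The estimated value for compound 4 is 10000 nM, with a range from 4000 nM to 30000 nM.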

Compound 4, concentration for 50% growth inhibition: 10700 nM
Compound 4: the middle estimate sits 1.1-fold (0.03 log units) below what was measured, within the range that was stated.
By their numbers in this assay, from the lowest: compounds 4 and 3 (each within the scatter of the next); then compound 2. At a limit, above all of these: compound 1.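

In this assay, with the group on the aromatic carbon between two ring nitrogen atoms, the exchange of the ring oxygen for sulfur gives a 1.1-fold lower number from compound 3 to compound 4 (0.04 log units; within the scatter), so the lower numbers are not tied to furan-3-yl alone. Against cyclopropyl, thiophen-3-yl gives a 9.0-fold lower number from compound 2 to compound 4 (0.95 log units; beyond the scatter), much as furan-3-yl did. The step against isopropyl, an at least 9.3-fold lower number from compound 1 to compound 4 (0.97 log units; beyond the scatter), is only a floor, as compound 1 stands at a limit: the limit of > 100000 nM in this assay, at which 1 of the 4 values shown sits.

Left open is whether a phenyl or pyridin-3-yl group at this position would lower the number further. Also open, on these data alone, is how a carboxylic acid in place of the methoxycarbonyl group would read.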